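A Third Methoxy Group Added to a Limit-Bound Compound

This account rests on a few compounds, and the source may have more. Where it says the series, first, only, none or still open, it means among the compounds named here.

compound 1, `O=C(/C=C\Nc1ccc(C(F)(F)F)cc1)c1cn(-c2ccccc2)nc1-c1ccccc1`: > 50000 nM in a functional assay on U-87MG ATCC cells (Homo sapiens) for antiproliferative activity, read by MTT assay, with a stated time of 48 h; a lower number here means a stronger inhibitor, a higher number a weaker inhibitor
compound 2, `COc1ccc(-c2nn(-c3ccccc3)cc2C(=O)/C=C\Nc2ccc(Cl)cc2)cc1`: 8860 nM
compound 3, `COc1ccc(-c2nn(-c3ccccc3)cc2C(=O)/C=C\Nc2ccc(C(F)(F)F)cc2)cc1`: > 50000 nM

Compound 3 sits at a limit of this assay: its value, > 50000 nM, is a limit and not a number. Compound 1 also stands at a limit with > 50000 nM. Among the three measured compounds only compound 2 gives a number, 8860 nM.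

Compound 4, `COc1cc(-c2nn(-c3ccccc3)cc2C(=O)/C=C\Nc2ccc(C(F)(F)F)cc2)cc(OC)c1OC`, differs from compound 3 in one place: 3,4,5-trimethoxyphenyl in place of 4-methoxyphenyl on an aromatic carbon.

Two measured steps reach compound 3. The step that the two limits leave unreadable from compound 1 to compound 3 cannot be sized, as both ends sit at the limit. The step of an at least 5.6-fold higher number from compound 2 to compound 3 (0.75 log units; beyond the scatter) concerns the trifluoromethyl group, which compound 4 keeps, and so says nothing about the change in the methoxy count. No measured step touches the 3,4,5-trimethoxyphenyl group itself, and the shared limit, (the limit of > 50000 nM in this assay, at which 2 of the 3 values shown sit), leaves the starting point open; any reading of this step therefore rests on assumption rather than on the shown pairs.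

In this assay compound 4 is expected to give 30000 nM, with a range from 5000 nM to 100000 nM, which would mean an estimated step of an at least 1.6-fold lower number from compound 3 to compound 4 (0.22 log units; that floor lies within the scatter). It is also quite possible, in my expectation, that compound 4 would again sit only at the limit of this assay rather than give a number.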

Compound 4, half-maximal inhibitory concentration: > 50000 nM
Compound 4: no number, only a limit; the forecaster's own chance of this, stated with the estimate: 50%; middle value at least 1.6-fold (0.22 log units) away from the limit.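

In this assay compound 4 gives > 50000 nM, which is a limit and not a number. The steps to compound 4 from compound 3 and from compound 1 therefore cannot be read: the limit of > 50000 nM in this assay, at which 3 of the 4 values shown sit.

The compounds shown leave open whether 3,4,5-trimethoxyphenyl in place of 4-methoxyphenyl changes the result at all in this assay.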